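Linker Length and Hexokinase-1 Inhibition at a Single Concentration

A few compounds are considered here, and "the series" means these few. Any claim that something is new, unique, unknown or untested is made for them only; others in the source may bear on it.

Measured compounds:
Compound 1 `O=C(CI)NCCCCC(=O)NCCCCCCNc1ncnc2c1ncn2[C@@H]1O[C@H](COP(=O)(O)OP(=O)(O)OP(=O)(O)O)[C@@H](O)[C@H]1O` gives 0%
Compound 2 `O=C(CI)NCCCC(=O)NCCCCCCNc1ncnc2c1ncn2[C@@H]1O[C@H](COP(=O)(O)OP(=O)(O)OP(=O)(O)O)[C@@H](O)[C@H]1O` gives 0%
Compound 3 `O=C(CI)NCCCCCCCNc1ncnc2c1ncn2[C@@H]1O[C@H](COP(=O)(O)OP(=O)(O)OP(=O)(O)O)[C@@H](O)[C@H]1O` gives 20%

In an assay on isolated protein for inhibition of hexokinase-1 (Rattus norvegicus), with a stated time of 6 h, tested at 10 mM (on this read-out higher numbers stand for more inhibition at the one concentration tested (going by the name of the read-out) and lower numbers for less inhibition), compound 3 stands highest of the three numbers. The steps of a number 20 percentage points higher from compound 1 to compound 3 (beyond the scatter) and a number 20 percentage points higher from compound 2 to compound 3 (beyond the scatter) both replaced a longer chain with a shorter one and both raised the read-out beyond the scatter, while no change at the digits printed from compound 1 to compound 2 (within the scatter) stayed within it. Compound 4 `O=C(CI)NCCNc1ncnc2c1ncn2[C@@H]1O[C@H](COP(=O)(O)OP(=O)(O)OP(=O)(O)O)[C@@H](O)[C@H]1O` continues in the same direction: ((iodomethyl)carbonyl)amino in place of 5-(((iodomethyl)carbonyl)amino)pentyl on a saturated chain carbon, two bonds along the chain from a nitrogen on an aromatic ring. The two steps that bear on it were each modest and upward, so a further modest rise, or at least no fall, is expected for compound 4 in this assay. Compound 4 is therefore estimated at 30%, within a range from 5% to 60%, which means an expected step of a number 10 percentage points higher from compound 3 to compound 4 (within the scatter).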

Compound 4, a percentage reported as inhibition, at one concentration (the size of the read-out at that concentration, not a potency): 0%
The estimate for compound 4 lay 30 percentage points above the measured number; measured number outside the range, below it.
By their numbers in this assay, from the lowest: compounds 1, 2 and 4 (each within the scatter of the next); then compound 3.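

In this assay, cutting the chain back to ((iodomethyl)carbonyl)amino gave a number 20 percentage points lower from compound 3 to compound 4 (beyond the scatter), so shortening at this position does not raise the read-out without limit. The earlier upward steps to compound 3 therefore describe no single trend with chain length, and compound 4 goes against any such trend. Nothing available accounts for this reversal. Still open, as far as these compounds go, is how a butyl or propyl chain carrying the same end group would read, and whether an acetyl amide in place of the iodomethyl carbonyl group would retain the read-out of compound 3.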